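The source may hold more compounds than are shown below. What is called first, only, known or untested is meant among the compounds shown, and "the series" means these compounds.

Measured so far in an ADME assay on microsomes from liver (Mus musculus) for metabolic stability, using NADPH, with a stated time of 10 min (on this read-out lower numbers stand for a less stable compound and higher numbers for a more stable compound), for this series:
- compound 1 `NCCCCN(C[C@H]1Cc2cccnc2CN1)[C@H]1CCCc2cccnc21` gives 69%
- compound 2 `NCCCCN(C[C@@H]1Cc2nccnc2CN1)[C@H]1CCCc2cccnc21` gives 73%
- compound 3 `CN(C[C@H]1Cc2ncccc2CN1)[C@H]1CCCc2cccnc21` gives 53%

Compound 3 stands lowest of the three, and both compound 1 and compound 2 lie above it by more than the usual scatter. The next compound to be tested is compound 4 `CN(C)CCCCN(C[C@H]1Cc2ncccc2CN1)[C@H]1CCCc2cccnc21`, which keeps the core of compound 3. The change is 3-(dimethylamino)propyl in place of hydrogen on a saturated chain carbon bound to an amine nitrogen with 3-(dimethylamino)propyl in place of hydrogen on a saturated chain carbon bound to an amine nitrogen. Among the measured compounds shown here, no measured pair isolates this kind of change. The nearest guide is that compound 1 at 69% and compound 2 at 73% also carry a longer chain, though their cores differ from that of compound 3 as well. A small upward move is therefore expected in this assay, with the estimated step of a number 7 percentage points higher from compound 3 to compound 4 (within the scatter) staying within the scatter. Compound 4 is estimated at 60%, with an expected range from 42% to 78% in this measurement.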

Compound 4, percent of the compound remaining: 55%
Compound 4: middle estimate off by 5 percentage points, on the high side; the range from low to high includes it.
By their numbers in this assay, from the lowest: compounds 3 and 4 (each within the scatter of the next); then compounds 1 and 2 (each within the scatter of the next).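

In this assay, the place on a saturated chain carbon bound to an amine nitrogen now has its first single-change comparison: 3-(dimethylamino)propyl in place of hydrogen gives a number 2 percentage points higher from compound 3 to compound 4 (within the scatter). Among the compounds shown here, on the core of compound 3, this read-out therefore does not separate the short group from the full chain ending in a dimethylamino group, something the earlier compounds could not show, as their cores differ as well as their chains. Nothing measured here gives a reason for this result.

Going by these compounds, whether the same change would read alike on the cores of compound 1 and compound 2 remains open. So does the reading at this place for a chain ending in a carboxylic acid or a hydroxyl group, or for a chain carrying a piperidine ring.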